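This account rests on a few compounds, and the source may have more. Where it says the series, first, only, none or still open, it means among the compounds named here.

In a functional assay on NCI-H1993 cells (Homo sapiens) for inhibition, read by CCK-8 assay, with a stated time of 72 h (on this read-out higher numbers stand for weaker inhibition and lower numbers for stronger inhibition), compound 1 `CCC(c1ccc2ncccc2c1F)n1cnc2ncc(-c3cn[nH]c3)nc21` has the entry "not determined" (no result reported), so it offers no number for comparison. Compound 2 `c1cnc2ccc(Cn3cnc4ncc(-c5cn[nH]c5)nc43)cc2c1` gives 2890 nM. Among the compounds with values here, this is the only number available, so it cannot yet be called high or low among related compounds. Compound 3 `C1=C(c2cnc3ncn(Cc4ccc5ncccc5c4)c3n2)CCNC1` keeps the rest of compound 2 and changes a single group: a group of 6 heavy atoms (5 carbon, 1 nitrogen; one six-membered non-aromatic ring with 1 hetero atom) in place of a group of 5 heavy atoms (3 carbon, 2 nitrogen; one five-membered aromatic ring with 2 hetero atoms), on an aromatic carbon. The 1H-pyrazol-4-yl group, a five-membered aromatic ring, gives way to a six-membered non-aromatic ring with 1 hetero atom and 1 double bond outside aromatic rings. The change sits on an aromatic carbon of the six-membered aromatic ring with 2 nitrogen. Within the data shown here, no pair of measured compounds shows what such a swap does, so any forecast is a judgement rather than a reading of the data. A modest loss of inhibition seems the most likely outcome, although a change within the usual scatter would be no surprise. The estimated change is a 2.1-fold higher number from compound 2 to compound 3 (0.32 log units; beyond the scatter). For compound 3 the expected value is 6000 nM, with an estimated range from 2000 nM to 18000 nM.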

Compound 3, half-maximal inhibitory concentration: 6660 nM
Compound 3: the middle estimate sits 1.1-fold (0.05 log units) below what was measured; measured number inside the range.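

In this assay, the step from the 1H-pyrazol-4-yl group to the six-membered non-aromatic ring is a 2.3-fold higher number from compound 2 to compound 3 (0.36 log units; beyond the scatter), so this position does respond to the swap, although the loss is modest and an aromatic five-membered ring is not needed to obtain a measurable value. Both groups carry the same counts of hydrogen-bond donors and acceptors, so the step comes with a change in ring size and the loss of aromaticity, and this single pair cannot separate those two changes from each other. Nothing measured here explains why the number rises.

It remains open whether the double bond itself matters, since the compounds shown do not include the fully saturated piperidine ring at this place, which would test that directly. It is also unclear how a morpholine ring or an open-chain amine would read here, and with one step at this position no trend can be claimed for groups at this site in general.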